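The compounds below may be only part of what the source reports. "The series", "measured", "known", "first", "only" and "open" are said of these compounds alone.

Compound 1 `CN(C)C(=O)c1cc2cnc(Nc3ccc(NC(=O)C4(C(=O)Nc5ccc(F)cc5)CC4)cc3)nc2n1C1CCCC1`: 49.8%
Compound 2 `CN(C)C(=O)c1cc2cnc(Nc3ccc(N)cn3)nc2n1C1CCCC1`: 3.7%

Both compounds were tested in a functional assay on HeLa cells (Homo sapiens) for inhibition, read by CCK-8 assay, with a stated time of 72 h, tested at 1 uM; a higher number here means more inhibition of growth at the concentration tested, a lower number less inhibition of growth. Compound 1 stands as the higher of the two, and compound 2 lies beyond the scatter beneath it. For the measured compounds named here, no two measured compounds differ in one place only, so the data offer no direct measure of what a single change does.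

The next compound to be tested is compound 3 `CN(C)C(=O)c1cc2cnc(Nc3ccc(NC(=O)C4(C(=O)Nc5cccc(O)c5)CC4)cc3)nc2n1C1CCCC1`. It keeps everything in compound 1 except one group, with 3-hydroxyphenyl in place of 4-fluorophenyl on an amide-type nitrogen. Going by the values given here, with no comparable step to draw on, the best anchor is compound 1 at 49.8%, and the expectation stays close to that value while allowing for real uncertainty in either direction.

The step expected in this assay is small and slightly downward, an estimated a number 4.8 percentage points lower from compound 1 to compound 3 (within the scatter), which would not lie beyond the scatter. For compound 3 the estimated value is 45%, with an expected range of 25% to 65%.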

Compound 3, percent growth inhibition at one concentration: 57%
Compound 3: middle estimate off by 12 percentage points, on the low side; measured number inside the range.
By their numbers in this assay, from the lowest: compound 2; then compounds 1 and 3 (each within the scatter of the next).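

In this assay, putting 3-hydroxyphenyl in place of 4-fluorophenyl on the amide-type nitrogen gives a number 7.2 percentage points higher from compound 1 to compound 3 (within the scatter), so this read-out does not separate the two groups at this position. For the compounds shown here, this is the first comparison that differs in one place only, and it shows that a phenyl group bearing a hydroxyl, with one hydrogen-bond donor and one acceptor, can take the place of a fluorinated phenyl group with neither, without a step beyond the scatter. No measurement at hand accounts for this outcome.

The single swap changes both the substituent and its printed ring position, so the compounds shown leave open what each of these contributes, a question that 4-hydroxyphenyl and 3-fluorophenyl at the same nitrogen would address. Also open, as far as these compounds go, is whether 3-aminophenyl or 3-carboxyphenyl would stay within the scatter of compound 3 in this assay, or whether either would produce a clear step at this position.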